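From methylsulfanyl to ethoxy: what to expect

The source may hold more compounds than are shown below. What is called first, only, known or untested is meant among the compounds shown, and "the series" means these compounds.

Of the compounds shown here, three have been tested in a functional assay on MLM cells (Homo sapiens) for cytotoxicity, using microsomes; on this read-out lower numbers stand for an effect already at smaller amounts and higher numbers for an effect only at larger amounts of compound. Compound 1 `COc1cc(/C=C/c2ccc(C(C)(C)C)cc2)cc(OC)c1OC` gives > 25 uM in this assay, which is a limit rather than a number. Compound 2 `COc1cc(/C=C/c2ccc(C(C)C)cc2)cc(OC)c1OC` likewise gives > 25 uM, again a limit. For the measured compounds named here, compound 3 `COc1cc(/C=C/c2ccc(SC)cc2)cc(OC)c1OC` gives 7.3 uM, the only real number among the three, so it stands alone as the one compound with a measured effect.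

The two readable steps both end at compound 3: an at least 3.4-fold lower number from compound 1 to compound 3 (0.53 log units; beyond the scatter) and an at least 3.4-fold lower number from compound 2 to compound 3 (0.53 log units; beyond the scatter). The step that the two limits leave unreadable from compound 1 to compound 2 cannot be read because of the limit of > 25 uM in this assay, at which 2 of the 3 values shown sit.

Compound 4 `CCOc1ccc(/C=C/c2cc(OC)c(OC)c(OC)c2)cc1` differs from compound 3 by ethoxy in place of methylsulfanyl on an aromatic carbon. Going by the values given here, no measured step replaces methylsulfanyl by ethoxy, so the earlier steps only show that methylsulfanyl gave a smaller number than two alkyl groups; they do not say how ethoxy compares. The estimated step of a 2.1-fold higher number from compound 3 to compound 4 (0.31 log units; beyond the scatter) is therefore expected to lean toward a higher number, with wide uncertainty. Compound 4 is expected to give about 15 uM, within 5 uM to 30 uM.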

Compound 4, concentration for half-maximal effect: 2.2 uM
Compound 4: the middle estimate sits 6.8-fold (0.83 log units) above what was measured, outside the stated range (below it).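

In this assay, ethoxy in place of methylsulfanyl on this aromatic carbon, para to a large group, gives a 3.3-fold lower number from compound 3 to compound 4 (0.52 log units; beyond the scatter), so the sulfur of compound 3 is not needed for an effect at this position. Measured against the two alkyl groups, ethoxy gives an at least 11-fold lower number from compound 2 to compound 4 (1.05 log units; beyond the scatter) when it replaces isopropyl and an at least 11-fold lower number from compound 1 to compound 4 (1.05 log units; beyond the scatter) when it replaces tert-butyl. Both of these larger steps start from a limit rather than a number, so their true size stays open: the limit of > 25 uM in this assay, at which 2 of the 4 values shown sit.

Ethoxy differs from methylsulfanyl in both its linking atom and its chain, and the compounds shown do not separate these two changes. As far as these compounds go, it also remains open how a longer chain such as propoxy, or an amine, would read at this position.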